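Adding a second fluoro group to compound 2

A few compounds are considered here, and "the series" means these few. Any claim that something is new, unique, unknown or untested is made for them only; others in the source may bear on it.

Measured so far in a functional assay on Raji cells (Homo sapiens) for cytotoxicity, with a stated time of 72 h; a higher number here means that more compound is needed for the effect, a lower number that less compound is needed (both values are limits)
- compound 1 `C=C[C@@](C)(/C=C/c1ccc(Nc2ccc(OC)cc2)cc1)CCC=C(C)C` gives > 26000 nM (a limit)
- compound 2 `C=C[C@@](C)(/C=C/c1ccc(Nc2ccc(F)cc2)cc1)CCC=C(C)C` gives > 26000 nM (a limit)

Compound 2 has no number to its name, only the limit > 26000 nM in this assay. Within the data shown here, the series so far reads (the limit of > 26000 nM in this assay, at which 2 of the 2 values shown sit). The change under study leads to compound 3 `C=C[C@@](C)(/C=C/c1ccc(Nc2ccc(F)c(F)c2)cc1)CCC=C(C)C` and is fluoro in place of hydrogen on an aromatic carbon. This is fluoro in place of hydrogen on an aromatic carbon, taking 4-fluorophenyl to 3,4-difluorophenyl. Among the measured compounds shown here, the one measured step that bears on it is a step that the two limits leave unreadable from compound 1 to compound 2, also a change on an aromatic carbon. That step gives no size to carry over and no direction. No step beyond the usual scatter is therefore expected in this assay, and compound 3 will most likely also be reported only as a limit. Should a number be returned, the expected result is a step that the limit leaves unreadable from compound 2 to compound 3. The estimate for compound 3 is 30000 nM, with an expected range from 13000 nM to 70000 nM.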

Compound 3, half-maximal effective concentration: > 26000 nM
Compound 3 was reported as a limit; the forecaster's own chance of this, stated with the estimate: 85%; the middle value is on the limit's open side.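

In this assay compound 3 gives > 26000 nM, which is a limit and not a number. No step can be read between compound 3 and either compound 1 or compound 2, because all three sit at the same limit: the limit of > 26000 nM in this assay, at which 3 of the 3 values shown sit.

The compounds shown leave open whether any of these aromatic substitutions changes the half-maximal effective concentration.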